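This account rests on a few compounds, and the source may have more. Where it says the series, first, only, none or still open, it means among the compounds named here.

Three compounds have been measured in a functional assay on microsomes for inhibition, with a stated time of 1 h; a higher number here means a weaker inhibitor, a lower number a stronger inhibitor:

Compound 1, `Cn1c(NN)nc(-c2ccco2)c(C#N)c1=O`: 78 ug/mL
Compound 2, `Cn1c(NN)nc(-c2ccc(Cl)cc2)c(C#N)c1=O`: 46 ug/mL
Compound 3, `CCOC(=O)c1cnn(-c2nc(-c3cccs3)c(C#N)c(=O)n2C)c1N`: 97 ug/mL

Compound 3 stands highest of the three numbers. Its gap to compound 1 lies within the usual scatter of repeated measurements, so those two cannot be told apart. Its gap to compound 2 lies beyond the scatter, so compound 2 is the stronger inhibitor of the pair.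

Compound 4, `CCOC(=O)c1cnn(-c2nc(-c3ccc(N(C)C)cc3)c(C#N)c(=O)n2C)c1N`, is the next compound to be measured. It differs from compound 3 in one place: 4-(dimethylamino)phenyl in place of thiophen-2-yl on an aromatic carbon. Among the compounds with values here, the group that enters is, like the one in compound 2, a six-membered aromatic ring of carbon only, and compound 2 gives 46 ug/mL while the five-ring compound 1 gives 78 ug/mL. Within the data shown here, no direct step between two measured compounds covers this kind of change, so the expectation rests on that loose parallel alone. A modest step toward a lower number is expected, though one that may not clear the scatter.

Compound 4 is expected to give about 65 ug/mL in this assay, with a likely range from 30 ug/mL to 140 ug/mL. That estimate means an expected step of a 1.5-fold lower number from compound 3 to compound 4 (0.17 log units; within the scatter).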

Compound 4, half-maximal inhibitory concentration: 111 ug/mL
Compound 4: the middle estimate sits 1.7-fold (0.23 log units) below what was measured; measured number inside the range.
By their numbers in this assay, from the lowest: compounds 2, 1, 3 and 4 (each within the scatter of the next, the first and the last beyond it).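

In this assay, placing 4-(dimethylamino)phenyl in place of thiophen-2-yl on this aromatic carbon gives a 1.1-fold higher number from compound 3 to compound 4 (0.06 log units; within the scatter), a step that cannot be told apart from no change at all. This is the only pair shown in which this position changes while the rest of the molecule stays the same, and it shows that a five-membered aromatic ring with one hetero atom and a larger six-membered aromatic ring of carbon only can be exchanged here without a readable gain or loss in inhibition. No measurement shown bears on why the step is so small.

Two things changed together in this step, the ring and the dimethylamino group on it, so a plain phenyl ring on the same carbon would be needed to separate them. As far as these compounds go, it also remains open whether this flat result would hold for quite different groups at this position, such as a pyridine ring, a carboxylic acid or a short alkyl chain.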